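What Happens When Compound 2 Loses Its Isopropyl Group?

This account rests on a few compounds, and the source may have more. Where it says the series, first, only, none or still open, it means among the compounds named here.

In a functional assay on HBL-100 cells (Homo sapiens) for antiproliferative activity, read by sulforhodamine B assay, with a stated time of 48 h (a lower number here means a stronger inhibitor of growth, a higher number a weaker inhibitor of growth), compound 1 `CCOC(=O)C#CC(O/C=C/C(=O)OCC)C(C)C` gives 3000 nM, while compound 2 `CCOC(=O)C#CC(O/C=C/C(=O)OC)C(C)C` gives 880 nM, the lower of the two numbers and so the stronger growth inhibition. Compound 3 `CCOC(=O)C#CCO/C=C/C(=O)OC` has not yet been measured. It differs from compound 2 at one place hydrogen in place of isopropyl on a saturated chain carbon bound to an oxygen on an unsaturated carbon and a triple-bonded carbon.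

Within the data shown here, only one measured step offers any guide, and it lies elsewhere in the structure: a 3.4-fold lower number from compound 1 to compound 2 (0.53 log units; beyond the scatter). That modest step, beyond the scatter, came from hydrogen in place of methyl on a saturated chain carbon bound to an oxygen next to a carbonyl group. Among the measured compounds shown here, no measured pair tests the isopropyl group itself, so the direction remains open. Only a slight lean towards a lower number is expected, with no confident step beyond the scatter. The estimated change is a 1.5-fold lower number from compound 2 to compound 3 (0.17 log units; within the scatter). In this assay, the expected value for compound 3 is 600 nM, with an estimated range of 150 nM to 2500 nM.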

Compound 3, concentration for 50% growth inhibition: 2400 nM
Estimate against measurement, compound 3: 4.0-fold (0.60 log units) below; low and high end bracket the measured number.
By their numbers in this assay, from the lowest: compound 2; then compounds 3 and 1 (each within the scatter of the next).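

Among these compounds, this is the first look at the position itself, since the earlier step lay elsewhere in the structure. In this assay, replacing isopropyl with hydrogen on the saturated chain carbon bound to an oxygen on an unsaturated carbon and a triple-bonded carbon weakens growth inhibition (a 2.7-fold higher number from compound 2 to compound 3 (0.44 log units; beyond the scatter)), a modest change but one beyond the scatter, so what sits at this carbon does affect the result, and here isopropyl gives the stronger compound of the pair. Nothing available explains why this change has that effect.

From the compounds shown here alone, with only isopropyl and hydrogen to compare, a single step marks two end points and no trend, so it remains open whether a methyl, a longer chain such as n-butyl, a phenyl ring or a chain ending in an amine would give a lower or a higher number than isopropyl. Among the compounds shown here, it is also open whether the same replacement would have a similar effect on compound 1, which carries the other ester, as the step so far rests on a single pair of compounds.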